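Isobutyl to sec-butyl on an amine nitrogen: what to expect

This account rests on a few compounds, and the source may have more. Where it says the series, first, only, none or still open, it means among the compounds named here.

Compound 1 `CC(C)CNC(=C\C(=O)/C=C/c1ccc(O)cc1)/C=C/c1ccc(O)cc1` and compound 3 `CCC(C)NC(=C\C(=O)/C=C/c1ccc(O)cc1)/C=C/c1ccc(O)cc1` share one core and differ in a single place: sec-butyl in place of isobutyl on an amine nitrogen. In a functional assay on EA.hy 926 cells (Homo sapiens), read by fluorescence, tested at 1 uM (on this read-out lower numbers stand for a weaker effect and higher numbers for a stronger effect at the one concentration tested), compound 1 gives 100%, and in the same assay compound 3 gives 99%, so that a number 1 percentage points lower from compound 1 to compound 3 (within the scatter). Compound 2 `COc1cc(/C=C/C(=O)/C=C(/C=C/c2ccc(OC(C)=O)c(OC)c2)NCC(C)C)ccc1OC(C)=O` is built on a second core; how the two cores differ is not broken down here. In this assay compound 2 gives 104%. Compound 4 `CCC(C)NC(=C\C(=O)/C=C/c1ccc(OC(C)=O)c(OC)c1)/C=C/c1ccc(OC(C)=O)c(OC)c1` has not been measured; it relates to compound 2 as compound 3 relates to compound 1, by sec-butyl in place of isobutyl on an amine nitrogen, at a place described in the same words, so the change is the same. Because a number 1 percentage points lower from compound 1 to compound 3 (within the scatter), the step from compound 2 to compound 4 is expected to be a number 1 percentage points lower from compound 2 to compound 4 (within the scatter). Compound 4 is therefore estimated to give 103%, between 93% and 113%.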

Compound 4, a percentage reported as activity, at one concentration (the size of the read-out at that concentration, not a potency): 68%
Estimate against measurement, compound 4: 35 percentage points above, outside the stated range (below it).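

On the second core, sec-butyl in place of isobutyl on an amine nitrogen gives, in this assay, a number 36 percentage points lower from compound 2 to compound 4 (beyond the scatter). The size of this change therefore depends on the core that carries it, at least for these two pairs: the same change on two cores in this assay, a number 1 percentage points lower (within the scatter) from compound 1 to compound 3 and a number 36 percentage points lower (beyond the scatter) from compound 2 to compound 4, 35 percentage points apart, beyond the scatter of two such steps

This rests on one pair per core and does not show which difference between the cores is responsible, or how the change would behave on any further core. The compounds shown leave open how a cyclopropyl group or a longer chain on this amine nitrogen would fare on either core. Also open, on these data alone, is whether a core carrying only the acetoxy groups or only the methoxy groups would follow compound 1 and compound 3 or compound 2 and compound 4.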